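This account rests on a few compounds, and the source may have more. Where it says the series, first, only, none or still open, it means among the compounds named here.

Of the compounds shown here, three sharing one core have been tested in a functional assay on DU-145 cells (Homo sapiens) for inhibition, read by MTT assay, with a stated time of 24 h; a higher number here means a weaker inhibitor, a lower number a stronger inhibitor. Compound 1 `CCOC(=O)C1=Cc2ccccc2OC1(OCc1cn(CC(=O)Nc2ccc(C)cc2)nn1)C(F)(F)F` gives > 150000 nM in this assay, which is a limit of the assay rather than a number. Compound 3 `CCOC(=O)C1=Cc2ccccc2OC1(OCc1cn(-c2ccccc2)nn1)C(F)(F)F` likewise gives > 150000 nM, again a limit. The step that the two limits leave unreadable from compound 1 to compound 3, phenyl in place of ((4-methylphenyl)carbamoyl)methyl on an aromatic nitrogen, therefore cannot be read in either direction or size. Going by the values given here, compound 2 `CCOC(=O)C1=Cc2ccccc2OC1(OCc1cc(-c2ccc3ccccc3c2)no1)C(F)(F)F` gives 71800 nM in this assay; it is the only real number among the three, so it stands alone, while the other two sit at the limit of > 150000 nM in this assay, at which 2 of the 3 values shown sit.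

Compound 4 `CCOC(=O)C1=Cc2ccccc2OC1(OCc1cc(-c2ccc([N+](=O)[O-])cc2)no1)C(F)(F)F` has not yet been measured. It differs from compound 2 by 4-nitrophenyl in place of naphthalen-2-yl on an aromatic carbon. Among the compounds with values here, no measured step touches this position: the only step available, from compound 1 to compound 3, concerns a group on a different ring and is unreadable anyway. With nothing to point either way, the expected step of a 1.4-fold higher number from compound 2 to compound 4 (0.14 log units; within the scatter) is none beyond the usual scatter, and the estimate must be wide. Compound 4 is therefore expected to give about 100000 nM in this assay, with a range from 40000 nM to 250000 nM, and a real chance that only a limit is reported.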

Compound 4, half-maximal inhibitory concentration: > 150000 nM
Compound 4 ended at the assay's limit; the forecaster's own chance of this, stated with the estimate: 35%; middle value at least 1.5-fold (0.17 log units) from the limit.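

In this assay, going by these compounds alone, 4-nitrophenyl in place of naphthalen-2-yl gives an at least 2.0-fold higher number from compound 2 to compound 4 (0.31 log units; beyond the scatter), the first step that can be read, and it shows that this aromatic carbon, next to the ring nitrogen, is sensitive to which group it carries. In this assay, compound 4 gives > 150000 nM, which is a limit of the assay and not a number, and the step therefore has a minimum size but no known maximum. The change removes one of two six-membered aromatic rings of carbon only and brings in 2 hydrogen-bond acceptors in a single move, and this one step cannot separate the two differences.

Among the compounds shown, a real number at this position belongs to compound 2 alone, and how far the number can fall with a better group here remains open: the limit of > 150000 nM in this assay, at which 3 of the 4 values shown sit. Also open, from the compounds shown here alone, is whether a plain phenyl, or a phenyl carrying an amine or a carboxylic acid at the 4-position, would stay near compound 2 or reach the limit.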